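Exposure after removing the hydroxymethyl and adding a ring methyl

The source may hold more compounds than are shown below. What is called first, only, known or untested is meant among the compounds shown, and "the series" means these compounds.

Two compounds have numbers in an ADME assay on the whole organism (strain Sprague-Dawley) for pharmacokinetics, with Rattus norvegicus as the target, at a dose of 5 mg/kg by the oral route; on this read-out higher numbers stand for higher exposure at the dose given and lower numbers for lower exposure. Compound 1 `CC(C)c1ccc2c(Nc3cc(C(=O)N[C@@H](C)c4ccccc4)ccc3Sc3ccc(N)cc3)ncnc2n1` gives 2770 nM, and compound 2 `CC(C)c1ccc2c(Nc3cc(C(=O)N[C@@](C)(CO)c4ccccc4)ccc3Sc3ccc(N)cc3)ncnc2n1` gives 567 nM, the lowest of the two, which stands a 4.9-fold lower number from compound 1 to compound 2 (0.69 log units; beyond the scatter). Compound 3 `Cc1ccc([C@H](C)NC(=O)c2ccc(Sc3ccc(N)cc3)c(Nc3ncnc4nc(C(C)C)ccc34)c2)cc1` differs from compound 2 by 1-(4-methylphenyl)ethyl in place of 1-(hydroxymethyl)-1-phenylethyl on an amide-type nitrogen. Going by the values given here, this change undoes the hydroxymethyl that distinguished compound 2 from compound 1 and adds a methyl on the phenyl ring, for which no measured step exists. Compound 3 is therefore expected to rise roughly back toward compound 1, with a step of about a 3.5-fold higher number from compound 2 to compound 3 (0.55 log units; beyond the scatter) in this assay. The estimate for compound 3 is 2000 nM, with a range from 700 nM to 6000 nM.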

Compound 3, maximal plasma concentration: 292 nM
Compound 3: middle estimate off by 6.8-fold (0.84 log units), on the high side; the whole stated range lies above it.
By their numbers in this assay, from the lowest: compounds 3 and 2 (each within the scatter of the next); then compound 1.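

In this assay, the methyl in place of hydrogen on an aromatic carbon gives a 9.5-fold lower number from compound 1 to compound 3 (0.98 log units; beyond the scatter), so this single small change on the phenyl ring is enough to move the number beyond the scatter. Exchanging 1-(hydroxymethyl)-1-phenylethyl for 1-(4-methylphenyl)ethyl gives a 1.9-fold lower number from compound 2 to compound 3 (0.29 log units; within the scatter), so the ring methyl leaves the number within the scatter of compound 2 even without the hydroxymethyl. No measured evidence accounts for this result. As far as these compounds go, whether a fluorine or a methoxy group on that aromatic carbon would give a similar step remains open.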